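Methoxy in place of methyl: compound 3 to compound 4

The compounds below may be only part of what the source reports. "The series", "measured", "known", "first", "only" and "open" are said of these compounds alone.

Of the compounds shown here, three have values so far. In a functional assay on U-373MG ATCC cells (Homo sapiens) for inhibition, read by colorimetric assay and MTT assay, with a stated time of 72 h (on this read-out higher numbers stand for weaker inhibition and lower numbers for stronger inhibition), compound 1 `Cn1c2cnc1OCCCCCCCCOc1cc3ccccc3cc1-2` gives 24000 nM, compound 2 `C=CCCCCOc1ccccc1-c1cnc(OCCC=C)n1C` gives 33000 nM and compound 3 `C=CCCCCOc1ccc(C)cc1-c1cnc(OCCC=C)n1C` gives 33000 nM. Compound 3 thus stands level with compound 2, and all three values lie within the scatter of one another.

The next structure is compound 4 `C=CCCCCOc1ccc(OC)cc1-c1cnc(OCCC=C)n1C`, with methoxy in place of methyl on an aromatic carbon, para to a (hex-5-en-1-yl)oxy group (methoxy in place of methyl on an aromatic carbon). For the measured compounds named here, the only measured step that bears on this change is no change at the digits printed from compound 2 to compound 3 (within the scatter), which came with methyl in place of hydrogen on an aromatic carbon. Going by the values given here, no measured compound carries methoxy at this place, so the evidence is thin. On this basis, no step beyond the scatter is expected in this assay, in either direction. The expected step is a 1.1-fold lower number from compound 3 to compound 4 (0.04 log units; within the scatter). The estimate for compound 4 is 30000 nM, with an expected range from 15000 nM to 60000 nM.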

Compound 4, half-maximal inhibitory concentration: 67000 nM
Estimate against measurement, compound 4: 2.2-fold (0.35 log units) below, outside the stated range (above it).
By their numbers in this assay, from the lowest: compounds 1, 2 and 3 (each within the scatter of the next); then compound 4.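

In this assay, the place para to a (hex-5-en-1-yl)oxy group now shows a response to substitution: methoxy in place of methyl gives a 2.0-fold higher number from compound 3 to compound 4 (0.31 log units; beyond the scatter) in a modest move toward weaker inhibition, and methoxy in place of hydrogen gives a 2.0-fold higher number from compound 2 to compound 4 (0.31 log units; beyond the scatter) in the same direction. The methyl step alone, no change at the digits printed from compound 2 to compound 3 (within the scatter) on its own, had shown no separation at this place, so the entering methoxy provides the first step here beyond the scatter. No measurement shown accounts for this shift.

On these data alone, whether a hydroxy group, an ethoxy group or a chlorine atom at this place would fall with methyl or with methoxy remains open. Also open, as far as these compounds go, is whether methoxy would produce a similar step on the core of compound 1.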